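The source may report more compounds than this note shows. Statements on the series, on what has been measured and on what is new or still open speak of the compounds shown alone.

Compound 1 `CCOC(=O)c1cc(-c2cccc(OCc3ccccc3Cl)c2)on1`: in an ADME assay on Vero cells (Chlorocebus sabaeus) for cytotoxicity, with a stated time of 72 h (on this read-out higher numbers stand for weaker inhibition and lower numbers for stronger inhibition), compound 1 gives > 128000 nM, which is a limit of the assay rather than a number.
Compound 2 `CCOC(=O)c1cc(-c2cccc(OCc3c(F)cccc3F)c2)on1`: in this assay compound 2 gives > 128000 nM, again a limit of the assay rather than a number.

The two compounds share one core and differ only in the ring carried on the saturated chain carbon bound to an oxygen on an aromatic ring. The step from compound 1 to compound 2 is a step that the two limits leave unreadable from compound 1 to compound 2, so whether that change moved the read-out at all cannot be told. Compound 2 therefore stands at the limit of > 128000 nM in this assay, at which 2 of the 2 values shown sit, and there is no number in the series to place it against. Compound 3 `CCOC(=O)c1cc(-c2cccc(OCc3ccc(F)c(F)c3F)c2)on1` has not yet been measured in this assay. The change is 2,3,4-trifluorophenyl in place of 2,6-difluorophenyl on a saturated chain carbon bound to an oxygen on an aromatic ring. Among the compounds with values here, the single measured step touches the same place, yet its size is unreadable, so it gives no direction and no size to lean on. With both measured compounds sitting at the limit, compound 3 is expected to sit there as well, with a step that the limit leaves unreadable from compound 2 to compound 3 as the expected step. The estimate for compound 3 is 150000 nM, with a range from 60000 nM to 400000 nM.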

Compound 3, half-maximal inhibitory concentration: > 128000 nM
Compound 3: only a limit was reported; the forecaster's own chance of this, stated with the estimate: 85%; the middle value is on the limit's open side.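

In this assay compound 3 gives > 128000 nM, which is a limit of the assay and not a number. No step among compound 1, compound 2 and compound 3 can therefore be read: the limit of > 128000 nM in this assay, at which 3 of the 3 values shown sit.

The compounds shown leave open the concentration at which any of them would inhibit the cells, and whether changing the ring shifts it.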